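Piperidine to methylpiperazine swap on a second quinazoline core

This account rests on a few compounds, and the source may have more. Where it says the series, first, only, none or still open, it means among the compounds named here.

Measured compounds:
compound 1, `COc1cc2ncnc(N3CCc4ccccc43)c2cc1NC(=O)/C=C/CN1CCCCC1`, 4180 nM
compound 2, `COc1cc2ncnc(N3CCc4ccccc43)c2cc1NC(=O)/C=C/CN1CCN(C)CC1`, 9180 nM
compound 3, `COc1cc2ncnc(N3CCCc4ccccc43)c2cc1NC(=O)/C=C/CN1CCCCC1`, 5780 nM

All three were tested in a functional assay on PC-3 cells (Homo sapiens) for antiproliferative activity, read by MTT assay, with a stated time of 72 h; on this read-out lower numbers stand for stronger inhibition and higher numbers for weaker inhibition. Compound 1 and compound 2 share a core and differ only in one place: 4-methylpiperazin-1-yl in place of piperidin-1-yl on a saturated chain carbon bound to a double-bonded chain carbon. This change gave a 2.2-fold higher number from compound 1 to compound 2 (0.34 log units; beyond the scatter). Compound 3 carries a different core, and the difference between the two cores is 1,2,3,4-tetrahydroquinolin-1-yl in place of 2,3-dihydro-1H-indol-1-yl on an aromatic carbon. That change gave a 1.4-fold higher number from compound 1 to compound 3 (0.14 log units; within the scatter), so compound 1 and compound 3 cannot be told apart on this read-out.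

Compound 4, `COc1cc2ncnc(N3CCCc4ccccc43)c2cc1NC(=O)/C=C/CN1CCN(C)CC1`, is not yet measured. It differs from compound 3 by 4-methylpiperazin-1-yl in place of piperidin-1-yl on a saturated chain carbon bound to a double-bonded chain carbon. This is the same change that was made from compound 1 to compound 2, at the same place, and it occurs twice among these compounds. Because the change gave a 2.2-fold higher number from compound 1 to compound 2 (0.34 log units; beyond the scatter) on the first core, a step of similar size is expected on the second core, namely a 2.2-fold higher number from compound 3 to compound 4 (0.33 log units; beyond the scatter). This rests on a single measured pair, so the expectation is loose. Compound 4 is estimated to give 12500 nM in this assay, within 6000 nM to 26000 nM.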

Compound 4, half-maximal inhibitory concentration: 6260 nM
The estimate for compound 4 lay 2.0-fold (0.30 log units) above the measured number; the range from low to high includes it.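

Carried to the second core in this assay, the swap of piperidin-1-yl for 4-methylpiperazin-1-yl gave a 1.1-fold higher number from compound 3 to compound 4 (0.03 log units; within the scatter), and this step cannot be distinguished from the earlier one: the same change on two cores in this assay, a 2.2-fold higher number (0.34 log units; beyond the scatter) from compound 1 to compound 2 and a 1.1-fold higher number (0.03 log units; within the scatter) from compound 3 to compound 4, 2.0-fold (0.31 log units) apart, within the scatter of two such steps. With 4-methylpiperazin-1-yl in place, the change of core gave a 1.5-fold lower number from compound 2 to compound 4 (0.17 log units; within the scatter), and this too cannot be distinguished from its earlier counterpart: the same change on two cores in this assay, a 1.4-fold higher number (0.14 log units; within the scatter) from compound 1 to compound 3 and a 1.5-fold lower number (0.17 log units; within the scatter) from compound 2 to compound 4, 2.0-fold (0.31 log units) apart, within the scatter of two such steps. The two cores therefore give no sign that the swap behaves differently from one to the other, but this does not prove that it carries over unchanged, since its step is beyond the scatter on the first core and within it on the second, and one pair per core cannot fix its true size.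

The compounds shown leave open whether a morpholine ring or a dimethylamino group in the same place would follow the same course. They also leave open whether any of these steps would hold on a further core or in a different cell line.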